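Enamine ketone series: chloro to hydroxy on the aniline

The compounds below may be only part of what the source reports. "The series", "measured", "known", "first", "only" and "open" are said of these compounds alone.

Of the compounds shown here, two have been measured in a functional assay on HT-29 cells (Homo sapiens) for antiproliferative activity, read by MTT assay, with a stated time of 48 h (on this read-out lower numbers stand for stronger inhibition and higher numbers for weaker inhibition), so far. Compound 1 `O=C(/C=C\Nc1ccc(O)cc1)c1cn(-c2ccccc2)nc1-c1ccccc1` gives 5000 nM in this assay. Compound 2 `COc1ccc(-c2nn(-c3ccccc3)cc2C(=O)/C=C\Nc2ccc(Cl)cc2)cc1` gives 4760 nM in this assay, the lowest of the two numbers, yet within the scatter of compound 1. Compound 3 `COc1ccc(-c2nn(-c3ccccc3)cc2C(=O)/C=C\Nc2ccc(O)cc2)cc1` is not yet measured; it differs from compound 2 by hydroxy in place of chloro on an aromatic carbon. Among the compounds with values here, no comparable step between measured compounds exists, so nothing beyond the scatter is expected in either direction: the step from compound 2 to compound 3 is estimated at a 1.1-fold higher number from compound 2 to compound 3 (0.02 log units; within the scatter). Compound 3 is therefore expected near 5000 nM in this assay, between 2000 nM and 12000 nM.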

Compound 3, half-maximal inhibitory concentration: 2460 nM
For compound 3 the middle estimate is 2.0-fold (0.31 log units) above the measured one; low and high end bracket the measured number.
By their numbers in this assay, from the lowest: compounds 3, 2 and 1 (each within the scatter of the next, the first and the last beyond it).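

In this assay, hydroxy in place of chloro gives a 1.9-fold lower number from compound 2 to compound 3 (0.29 log units; within the scatter), so at this position, para to a large group, the two substituents are not separated. With hydroxy held constant, methoxy in place of hydrogen at a different place gives a 2.0-fold lower number from compound 1 to compound 3 (0.31 log units; beyond the scatter), a modest step and the only one so far beyond the scatter. No measurement at hand accounts for either step.

Open, from the compounds shown here alone, is whether an amine or a carboxylic acid at the hydroxy position would move the number beyond the scatter. Also open, going by these compounds, is whether the methoxy step holds with chloro on that ring.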